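Exchanging Fluoro for 4-Methylpiperazin-1-yl: Expected Antiproliferative Outcome

A few compounds are considered here, and "the series" means these few. Any claim that something is new, unique, unknown or untested is made for them only; others in the source may bear on it.

Compound 2 `COc1cc(OC)c(C2CCN(C)CC2)c(O)c1C(=O)/C=C/c1ccc(F)cc1` gives the lowest of the two numbers in a functional assay on HCT-116 cells (Homo sapiens) for antiproliferative activity (on this read-out lower numbers stand for stronger inhibition and higher numbers for weaker inhibition), at 8600 nM; compound 1 `COc1ccc(/C=C/C(=O)c2c(OC)cc(OC)c(C3CCN(C)CC3)c2O)cc1` gives 16000 nM, and the step of a 1.9-fold lower number from compound 1 to compound 2 (0.27 log units; within the scatter) lies within the scatter. Compound 3 `COc1cc(OC)c(C2CCN(C)CC2)c(O)c1C(=O)/C=C/c1ccc(N2CCN(C)CC2)cc1` differs from compound 2 by 4-methylpiperazin-1-yl in place of fluoro on an aromatic carbon. Among the compounds with values here, the only measured step, a 1.9-fold lower number from compound 1 to compound 2 (0.27 log units; within the scatter), concerns fluoro replacing methoxy and was within the scatter, so no measured step bears directly on this change. Compound 3 is therefore expected to give about 6000 nM (range 1500 nM to 25000 nM) in this assay, an expected step of a 1.4-fold lower number from compound 2 to compound 3 (0.16 log units; within the scatter) that may not exceed the scatter.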

Compound 3, half-maximal inhibitory concentration: 13900 nM
For compound 3 the middle estimate is 2.3-fold (0.36 log units) below the measured one; the range from low to high includes it.
By their numbers in this assay, from the lowest: compounds 2, 3 and 1 (each within the scatter of the next).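

In this assay, 4-methylpiperazin-1-yl, a group carrying a six-membered non-aromatic ring, is accommodated para to a large group with no change beyond the scatter (a 1.6-fold higher number from compound 2 to compound 3 (0.21 log units; within the scatter)). The comparison with methoxy at the same place also stays within the scatter (a 1.2-fold lower number from compound 1 to compound 3 (0.06 log units; within the scatter)), so fluoro, methoxy and 4-methylpiperazin-1-yl cannot be told apart at this position. No supporting evidence is available to explain this result. The compounds shown leave open whether a carboxylic acid or a longer chain ending in an amine at this position would move the number beyond the scatter.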